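The source may hold more compounds than are shown below. What is called first, only, known or untested is meant among the compounds shown, and "the series" means these compounds.

Going by the values given here, compound 1 `Cc1cc(S(=O)(=O)/N=C(\N)n2nccc2-c2ccccc2)c(SCc2ccc(Cl)cc2)cc1Cl` is one of three compounds measured in a functional assay on MCF7 cells (Homo sapiens) for cytotoxicity, read by MTT assay, with a stated time of 72 h (a higher number here means a weaker inhibitor, a lower number a stronger inhibitor), where compound 1 gives 75000 nM, the second highest of the three numbers. Compound 2 `Cc1cc(-c2ccccc2)n(/C(N)=N/S(=O)(=O)c2cc(C)c(Cl)cc2SCc2ccccc2C)n1` gives 80000 nM, within the scatter of compound 1. Among the compounds with values here, compound 3 `Cc1cc(-c2ccccc2)n(/C(N)=N/S(=O)(=O)c2cc(C)c(Cl)cc2SCc2ccc(C(F)(F)F)cc2)n1` gives 16000 nM, the lowest of the three, and the only measured step is a 5.0-fold lower number from compound 2 to compound 3 (0.70 log units; beyond the scatter). Compound 4 `Cc1cc(-c2ccccc2)n(/C(N)=N/S(=O)(=O)c2cc(C)c(Cl)cc2SCc2ccc(Cl)cc2)n1` differs from compound 1 by methyl in place of hydrogen on an aromatic carbon. Within the data shown here, no measured step concerns this change: the one step known alters the group on the saturated chain carbon bound to a sulfur, not the five-membered aromatic ring. With nothing bearing on it, compound 4 is expected to show no step beyond the scatter, no change at the digits printed from compound 1 to compound 4 (within the scatter). Compound 4 is therefore estimated at 75000 nM, within a range from 30000 nM to 190000 nM.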

Compound 4, half-maximal inhibitory concentration: 108000 nM
Compound 4: the middle estimate sits 1.4-fold (0.16 log units) below what was measured; low and high end bracket the measured number.
By their numbers in this assay, from the lowest: compound 3; then compounds 1, 2 and 4 (each within the scatter of the next).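

In this assay methyl in place of hydrogen on the aromatic carbon of the five-membered ring leaves the result within the scatter (a 1.4-fold higher number from compound 1 to compound 4 (0.16 log units; within the scatter)). With that methyl present, 4-chlorophenyl and 2-methylphenyl on the saturated chain carbon cannot be told apart (a 1.4-fold higher number from compound 2 to compound 4 (0.13 log units; within the scatter)), whereas chloro in place of trifluoromethyl on the aromatic carbon gives a step beyond the scatter (a 6.8-fold higher number from compound 3 to compound 4 (0.83 log units; beyond the scatter)). Nothing available explains these steps. From the compounds shown here alone, whether an amine or a carboxylic acid on that ring carbon would change the number remains open.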